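Fluoro for methyl on compound 2

This account rests on a few compounds, and the source may have more. Where it says the series, first, only, none or still open, it means among the compounds named here.

In a functional assay on MCF7 cells (Homo sapiens) for antiproliferative activity, read by MTT assay, with a stated time of 24 h (on this read-out lower numbers stand for stronger inhibition and higher numbers for weaker inhibition), compound 1 (`Cc1ccc(-c2nn(-c3ccccc3)cc2-c2nc3ccccc3n2S(=O)(=O)c2ccc(C)cc2)cc1`) gives 570 nM, compound 2 (`Cc1ccc(-c2nn(-c3ccccc3)cc2-c2nc3ccccc3n2S(=O)(=O)c2cc(C)ccc2C)cc1`) gives 510 nM and compound 3 (`Cc1ccc(-c2nn(-c3ccccc3)cc2-c2nc3ccccc3n2S(=O)(=O)c2ccc(F)cc2)cc1`) gives 5270 nM. Compound 2 thus stands with compound 1 at the low end of the three numbers, a 1.1-fold lower number from compound 1 to compound 2 (0.05 log units; within the scatter), and well under compound 3, a 10-fold higher number from compound 2 to compound 3 (1.01 log units; beyond the scatter). Compound 4 (`Cc1ccc(C)c(S(=O)(=O)n2c(-c3cn(-c4ccccc4)nc3-c3ccc(F)cc3)nc3ccccc32)c1`) differs from compound 2 by one change, (fluoro in place of methyl on an aromatic carbon), which reads 4-methylphenyl to 4-fluorophenyl. The closest evidence is the same swap on the group on the sulfonyl sulfur, a 9.2-fold higher number from compound 1 to compound 3 (0.97 log units; beyond the scatter). That swap lies at another place, so only part of its size is expected to carry over, as a rise in this assay. The expected step is a 2.9-fold higher number from compound 2 to compound 4 (0.47 log units; beyond the scatter). The estimated value for compound 4 is 1500 nM, with an expected range of 400 nM to 5500 nM.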

Compound 4, half-maximal inhibitory concentration: 430 nM
Estimate against measurement, compound 4: 3.5-fold (0.54 log units) above, within the range that was stated.
By their numbers in this assay, from the lowest: compounds 4, 2 and 1 (each within the scatter of the next); then compound 3.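

At the 4-methylphenyl carried by the shared core, rather than on the group on the sulfonyl sulfur, fluoro in place of methyl brings no loss in this assay: a 1.2-fold lower number from compound 2 to compound 4 (0.07 log units; within the scatter). This place therefore accepts a change that cost activity on the sulfonyl group, and the size of the swap at one place does not predict its size at the other: the same change on two cores in this assay, a 9.2-fold higher number (0.97 log units; beyond the scatter) from compound 1 to compound 3 and a 1.2-fold lower number (0.07 log units; within the scatter) from compound 2 to compound 4, 11-fold (1.04 log units) apart, beyond the scatter of two such steps

The compounds shown leave open whether this position accepts anything beyond methyl and fluoro, such as a methoxy group, an amine or a carboxylic acid.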